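This account rests on a few compounds, and the source may have more. Where it says the series, first, only, none or still open, it means among the compounds named here.

Measured so far in an ADME assay on MT4 cells (Homo sapiens) for cytotoxicity, read by MTT assay, with a stated time of 96 h; on this read-out higher numbers stand for lower toxicity in this test and lower numbers for higher toxicity in this test:
- compound 1 `O=[N+]([O-])c1cccc(/N=N/N2CCCC2)c1` gives 66000 nM
- compound 2 `CN(/N=N/c1ccccc1)c1ccccc1` gives 55000 nM
- compound 3 `c1ccc(/N=N/c2ccc(NC[C@@H]3CCCN4CCCC[C@H]34)c3c2CCCC3)cc1` gives 100000 nM

The three numbers lie within the usual scatter of one another, so compound 1 stands with compound 2 and compound 3 rather than apart from them; nothing in this set separates any of the three. Going by the values given here, no pair of the measured compounds differs in a single place, so no step is computed among them.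

Compound 4 `c1ccc(/N=N/N2CCCC2)cc1` is not yet measured. It differs from compound 1 in one place: hydrogen in place of nitro on an aromatic carbon. On the measured numbers nothing suggests that this change should move the number in this assay beyond the scatter in either direction. The expected step from compound 1 to compound 4 is therefore small, no change at the digits printed from compound 1 to compound 4 (within the scatter). Compound 4 is estimated at 66000 nM, with a range from 30000 nM to 140000 nM.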

Compound 4, half-maximal cytotoxic concentration: > 100000 nM
Compound 4 was reported as a limit; the forecaster's own chance of this, stated with the estimate: 30%; middle value at least 1.5-fold (0.18 log units) from the limit.
By their numbers in this assay, from the lowest: compounds 2, 1 and 3 (each within the scatter of the next).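

In this assay compound 4 gives > 100000 nM, which is a limit of the assay and not a number. Hydrogen in place of nitro on this aromatic carbon gives an at least 1.5-fold higher number from compound 1 to compound 4 (0.18 log units; that floor lies within the scatter), the first single-place step in the series, and it shows that the number does not depend on nitro being present to stay this high. The full size of the step cannot be read from the limit: the limit of > 100000 nM in this assay, at which 1 of the 4 values shown sits.

As far as these compounds go, whether an amine or a carboxylic acid on this aromatic carbon would move the number beyond the scatter remains open. So does whether a methoxy group there would.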